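Working notes: removing bromo from compound 2

A few compounds are considered here, and "the series" means these few. Any claim that something is new, unique, unknown or untested is made for them only; others in the source may bear on it.

Values in a functional assay on MCF7 cells (Homo sapiens) for cytotoxicity, read by MTT assay, with a stated time of 72 h (a lower number here means a stronger inhibitor, a higher number a weaker inhibitor), are as follows
Compound 1 `C[C@@H](Nc1c(C(=O)NCc2ccc(F)cc2)nc(Br)c2cccnc12)c1ccccc1` gives "not determined" (no result reported)
Compound 2 `NCCCNc1c(C(=O)NCc2ccc(F)cc2)nc(Br)c2cccnc12` gives 6000 nM
Compound 3 `Nc1ccc(Nc2c(C(=O)NCc3ccc(F)cc3)nc(Br)c3cccnc23)cc1` gives 4000 nM
Compound 4 `NCCCNc1c(C(=O)NCc2ccc(F)cc2)ncc2cccnc12` has not been measured

Among the compounds with values here, compound 2 gives 6000 nM and compound 3 gives 4000 nM here, so compound 2 stands level with the only other number, within the scatter. Compound 1 offers no number to set beside them.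

Compound 4 differs from compound 2 by hydrogen in place of bromo on an aromatic carbon in one place: hydrogen in place of bromo on an aromatic carbon, para to a (3-aminopropyl)amino group. Within the data shown here, the one measured step is a 1.5-fold lower number from compound 2 to compound 3 (0.18 log units; within the scatter) and it exchanges 3-aminopropyl for 4-aminophenyl on a nitrogen on an aromatic ring, leaving the bromo untouched. Among the measured compounds shown here, no measured pair shows the loss of bromo, so the data give neither its size nor its direction. In this assay no step beyond the scatter is expected, with wide uncertainty. The estimated step is a 1.2-fold higher number from compound 2 to compound 4 (0.07 log units; within the scatter) and its direction is not firm. Compound 4 is estimated at 7000 nM with an expected range from 2500 nM to 20000 nM in this measurement.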

Compound 4, half-maximal inhibitory concentration: > 10000 nM
Compound 4 ended at the assay's limit; the forecaster's own chance of this, stated with the estimate: 15%; middle value at least 1.4-fold (0.15 log units) from the limit.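

In this assay, compound 4 gives > 10000 nM, a limit of the assay and not a number. Hydrogen in place of bromo on this aromatic carbon, para to a (3-aminopropyl)amino group, gives an at least 1.6-fold higher number from compound 2 to compound 4 (0.22 log units; that floor lies within the scatter); this is the first reading at this position, as compound 1, compound 2 and compound 3 all keep the bromo and differ only in the group on the nitrogen. The change brings no lower number, its full size cannot be read, and compound 4 stands alone at the limit in this series: the limit of > 10000 nM in this assay, at which 1 of the 4 values shown sits.

Going by these compounds, what chlorine, a methyl group or an amine on this carbon would give remains open. Also open, on these data alone, is whether hydrogen in place of bromo would read the same alongside the 4-aminophenyl group of compound 3.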